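The source may hold more compounds than are shown below. What is called first, only, known or untested is meant among the compounds shown, and "the series" means these compounds.

Measured so far:
compound 2 `CC(O)CN(c1ccnc(Nc2ccc(C#N)cc2)n1)c1c(F)cc(-c2ccc(C#N)cc2)cc1F`, an ADME assay on MT4 cells (Homo sapiens) for cytotoxicity, read by MTT assay, with a stated time of 5 days (on this read-out lower numbers stand for higher toxicity in this test and higher numbers for lower toxicity in this test), 9800 nM
compound 1 `CCN(c1ccnc(Nc2ccc(C#N)cc2)n1)c1c(F)cc(-c2ccc(C#N)cc2)cc1F`, this assay 105000 nM

In this assay compound 2 gives 9800 nM, the lowest of the two numbers shown; its only neighbour, compound 1, gives 105000 nM. The next compound, compound 3 `N#Cc1ccc(Nc2nccc(N(CCCCl)c3c(F)cc(-c4ccc(C#N)cc4)cc3F)n2)cc1`, differs from compound 2 in one place: 2-chloroethyl in place of 1-hydroxyethyl on a saturated chain carbon bound to a nitrogen on an aromatic ring. Going by the values given here, the one measured step that bears on this is an 11-fold lower number from compound 1 to compound 2 (1.03 log units; beyond the scatter), in which the hydroxyl entered the chain. Here the hydroxyl leaves again, which on that step alone suggests a move back toward the number of compound 1, but chlorine enters at the same time and no measured step covers chlorine on this chain. The expectation is therefore an upward step from compound 2, smaller than the full step back and with wide uncertainty. Compound 3 is expected at 30000 nM, with a range from 8000 nM to 110000 nM. This estimate corresponds to an expected step of a 3.1-fold higher number from compound 2 to compound 3 (0.49 log units; beyond the scatter).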

Compound 3, half-maximal cytotoxic concentration: > 250000 nM
Compound 3 gave a limit, no number; the forecaster's own chance of this, stated with the estimate: 10%; middle value at least 8.3-fold (0.92 log units) from the limit.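

In this assay compound 3 gives a limit and not a number: the limit of > 250000 nM in this assay, at which 1 of the 3 values shown sits. The steps can still be read as bounds: 3-chloropropyl in place of 2-hydroxypropyl gives an at least 25-fold higher number from compound 2 to compound 3 (1.40 log units; beyond the scatter), and chloromethyl in place of hydrogen on the saturated chain carbon gives an at least 2.3-fold higher number from compound 1 to compound 3 (0.37 log units; beyond the scatter). A longer chain at this place therefore does not lower the number in itself, since compound 2 lies lower than compound 1 while compound 3 lies higher, so the direction depends on what the chain carries.

Going by these compounds, how large either step is beyond its bound stays open. Also open, on these data alone, is whether the change follows the loss of the hydroxyl or the entry of chlorine; a plain propyl chain, 3-hydroxypropyl or an amine at the chain end would separate the two.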